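Swapping the aryl group on a thiadiazole urea

This account rests on a few compounds, and the source may have more. Where it says the series, first, only, none or still open, it means among the compounds named here.

Three compounds share one core and differ only in the aryl group on an amide-type nitrogen. Compound 1 `O=C(Nc1cccc(Cl)c1)Nc1nnc(Sc2ncnc3scc(-c4ccncc4)c23)s1` gives 43900 nM in a functional assay on T47D cells (Homo sapiens) for antiproliferative activity, read by MTT assay, with a stated time of 48 h; on this read-out lower numbers stand for stronger inhibition and higher numbers for weaker inhibition. Compound 2 `Cc1ccc(NC(=O)Nc2nnc(Sc3ncnc4scc(-c5ccncc5)c34)s2)cc1` gives 17800 nM in this assay, and compound 3 `O=C(Nc1ccc(Cl)c(C(F)(F)F)c1)Nc1nnc(Sc2ncnc3scc(-c4ccncc4)c23)s1` gives 28000 nM in this assay. Among these three numbers compound 3 stands second highest; compound 1 is nearest to it and compound 2 furthest, yet both gaps lie within the scatter. Within the data shown here, the only step that crosses the scatter is a 2.5-fold lower number from compound 1 to compound 2 (0.39 log units; beyond the scatter), whereas a 1.6-fold lower number from compound 1 to compound 3 (0.20 log units; within the scatter) and a 1.6-fold higher number from compound 2 to compound 3 (0.20 log units; within the scatter) both stay inside it.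

Compound 4 `O=C(Nc1cccc(F)c1)Nc1nnc(Sc2ncnc3scc(-c4ccncc4)c23)s1` has not yet been measured. It differs from compound 3 by 3-fluorophenyl in place of 4-chloro-3-(trifluoromethyl)phenyl on an amide-type nitrogen. The step most relevant here is a 1.6-fold lower number from compound 1 to compound 3 (0.20 log units; within the scatter), since the 3-fluorophenyl entering compound 4 resembles the 3-chlorophenyl of compound 1, with fluorine in place of chlorine, and that step stayed within the scatter. The step of a 1.6-fold higher number from compound 2 to compound 3 (0.20 log units; within the scatter) likewise stayed within it. No change beyond the scatter is therefore expected in this assay. Because compound 1 gives 43900 nM, a similar number is expected for compound 4: 38000 nM in this assay, within a range from 15000 nM to 95000 nM. This estimate corresponds to an expected step of a 1.4-fold higher number from compound 3 to compound 4 (0.13 log units; within the scatter).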

Compound 4, half-maximal inhibitory concentration: 16700 nM
Estimate against measurement, compound 4: 2.3-fold (0.36 log units) above; low and high end bracket the measured number.
By their numbers in this assay, from the lowest: compounds 4, 2, 3 and 1 (each within the scatter of the next, the first and the last beyond it).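

In this assay, exchanging one halogen for another, fluoro in place of chloro on an aromatic carbon, gives a 2.6-fold lower number from compound 1 to compound 4 (0.42 log units; beyond the scatter), so the aryl group on the amide-type nitrogen can register a swap of a single atom. A far larger exchange does not separate the compounds: 3-fluorophenyl in place of 4-chloro-3-(trifluoromethyl)phenyl, which removes more heavy atoms, gives a 1.7-fold lower number from compound 3 to compound 4 (0.22 log units; within the scatter), and 3-fluorophenyl in place of 4-methylphenyl gives a 1.1-fold lower number from compound 2 to compound 4 (0.03 log units; within the scatter), both within the usual scatter, so among these four compounds the amount of the group that changes does not track the size of the step. No measurement is available to explain why the fluoro and chloro compounds part while the other pairs with compound 4 do not.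

The compounds shown leave open how a bromo or methoxy group would read in place of that fluoro, and whether fluoro at another place on the phenyl ring would read the same. They also leave open what an aryl group carrying an amine or a carboxylic acid, or a butyl chain in place of the aryl group, would do to the number.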